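The source may report more compounds than this note shows. Statements on the series, on what has been measured and on what is new or still open speak of the compounds shown alone.

Measured so far in a functional assay on SR cells (Homo sapiens) for inhibition, read by sulforhodamine B assay, with a stated time of 48 h; on this read-out lower numbers stand for stronger inhibition of growth and higher numbers for weaker inhibition of growth:
- compound 1, `Nc1cc(N)c2nc(-c3ccccc3)c(NCc3ccc(Cl)c(Cl)c3)nc2c1`, gives 1620 nM
- compound 2, `COc1ccc(CNc2nc3cc(N)cc(N)c3nc2-c2ccccc2)cc1OC`, gives 3310 nM

Among the measured compounds shown here, compound 2 stands at the higher of the two numbers, meaning weaker inhibition of growth; the only neighbour is compound 1, and the step of a 2.0-fold higher number from compound 1 to compound 2 (0.31 log units; beyond the scatter) is modest though beyond the scatter.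

Compound 3, `COc1cc(CNc2nc3cc(N)cc(N)c3nc2-c2ccccc2)cc(OC)c1OC`, differs from compound 2 by one change: methoxy in place of hydrogen on an aromatic carbon. It sits ortho to a methoxy group and meta to a methoxy group, on the ring carrying the two methoxy groups already present in compound 2.

For the measured compounds named here, no measured step matches this change. Going by the values given here, the single step known, from compound 1 to compound 2, swapped two chlorines for two methoxy groups on that ring and moved the number only modestly. Adding a third methoxy is a smaller change than that swap, so in this assay no step beyond the scatter is expected, with a slight lean toward a higher number. The expected step is a 1.1-fold higher number from compound 2 to compound 3 (0.06 log units; within the scatter). Compound 3 is estimated at 3800 nM, with a range from 1600 nM to 9000 nM.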

Compound 3, concentration for 50% growth inhibition: 891 nM
Beside the measured number, compound 3's estimate is 4.3-fold (0.63 log units) above it; measured number below the stated range.
By their numbers in this assay, from the lowest: compounds 3 and 1 (each within the scatter of the next); then compound 2.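

In this assay, methoxy in place of hydrogen on this aromatic carbon, ortho to a methoxy group and meta to a methoxy group, brings a 3.7-fold lower number from compound 2 to compound 3 (0.57 log units; beyond the scatter), which means stronger inhibition of growth. Among the compounds shown here, the only earlier step, a 2.0-fold higher number from compound 1 to compound 2 (0.31 log units; beyond the scatter), came from two methoxy groups replacing two chlorines on the same ring and pointed the other way, so the number does not simply rise as methoxy groups are put on this ring: a group of only 2 heavy atoms at this one place reverses that direction. Nothing measured here speaks to the reason for this change.

The compounds shown leave open whether the drop in the number belongs to methoxy itself, since no other group on this aromatic carbon can be compared, such as a hydroxy group, a fluorine, an amine or the longer ethoxy chain. They also leave open whether this methoxy would have the same effect without the two methoxy groups already on the ring, or with chlorines in their place.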